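Dropping the Methoxy Group: From Compound 2 to Compound 3

A few compounds are considered here, and "the series" means these few. Any claim that something is new, unique, unknown or untested is made for them only; others in the source may bear on it.

Compound 1 `CNc1cc(-c2c(C)nn(-c3nc(-c4ccc(Cl)c(Cl)c4)c(SC(C)C)s3)c2C(=O)O)ccn1`: 18000 nM
Compound 2 `COc1cc(Cl)cc(-c2c(C)nn(-c3nc(-c4ccc(Cl)c(Cl)c4)c(SC(C)C)s3)c2C(=O)O)c1`: 760 nM

In a functional assay on BJAB cells (Homo sapiens) for antiproliferative activity, with a stated time of 4 days (on this read-out higher numbers stand for an effect only at larger amounts of compound and lower numbers for an effect already at smaller amounts), compound 2 gives 760 nM, the lower of the two numbers measured, with compound 1 at 18000 nM. Compound 3 `Cc1nn(-c2nc(-c3ccc(Cl)c(Cl)c3)c(SC(C)C)s2)c(C(=O)O)c1-c1cccc(Cl)c1` differs from compound 2 by hydrogen in place of methoxy on an aromatic carbon. Going by the values given here, the only measured step, a 24-fold lower number from compound 1 to compound 2 (1.37 log units; beyond the scatter), exchanges the whole aryl group and so bears on this smaller change only loosely. A modest rise beyond the scatter is expected, a 2.0-fold higher number from compound 2 to compound 3 (0.30 log units; within the scatter). For compound 3 the estimate in this assay is 1500 nM, with a range from 400 nM to 6000 nM.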

Compound 3, half-maximal effective concentration: 13600 nM
For compound 3 the middle estimate is 9.1-fold (0.96 log units) below the measured one; the whole stated range lies below it.
By their numbers in this assay, from the lowest: compound 2; then compounds 3 and 1 (each within the scatter of the next).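

In this assay the methoxy group at this place counts for much of the earlier gain, since replacing it with hydrogen gives an 18-fold higher number from compound 2 to compound 3 (1.25 log units; beyond the scatter) as a large step. The chloro group alone does not hold that gain, as 3-chlorophenyl in place of 2-(methylamino)pyridin-4-yl gives only a 1.3-fold lower number from compound 1 to compound 3 (0.12 log units; within the scatter) in a step that lies within the scatter. Nothing at hand explains this result. On these data alone, whether an ethoxy group or an amine at this place would serve as the methoxy group does remains open. So does what the methoxy group would give without the chloro group.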